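Propyl for isopropyl on sulfur: toxicity limits in cell assay

The source may report more compounds than this note shows. Statements on the series, on what has been measured and on what is new or still open speak of the compounds shown alone.

Measured compounds:
- compound 1, `Cc1c(C(C)c2c(F)cccc2Cl)nc(SC(C)C)[nH]c1=O`: > 15000 nM
- compound 2, `CCCSc1nc(C(C)c2c(F)cccc2Cl)c(C)c(=O)[nH]1`: > 1500 nM
- compound 3, `CCc1c(C(C)c2c(F)cccc2Cl)nc(SC(C)C)[nH]c1=O`: > 3000 nM

The three measured compounds share one core and were tested in an ADME assay on MT4 cells (Homo sapiens) for activation, read by MTT assay; on this read-out lower numbers stand for higher toxicity in this test and higher numbers for lower toxicity in this test. For compound 1 the value > 15000 nM is a limit of the assay, not a number. For compound 2 the value > 1500 nM is likewise a limit. For compound 3 the value > 3000 nM is also a limit. The change from compound 1 to compound 2 is propyl in place of isopropyl on a sulfur and its step, a step that the two limits leave unreadable from compound 1 to compound 2, cannot be read because both ends are limits; the same holds for the limit of > 15000 nM in this assay, at which 1 of the 3 values shown sits, and the limit of > 1500 nM in this assay, at which 1 of the 3 values shown sits, taken together. The two cores differ by methyl in place of hydrogen on a saturated chain carbon bound to an aromatic carbon, and that step, a step that the two limits leave unreadable from compound 1 to compound 3, is equally unreadable.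

Compound 4, `CCCSc1nc(C(C)c2c(F)cccc2Cl)c(CC)c(=O)[nH]1`, has not been measured. Within the data shown here, it differs from compound 3 by propyl in place of isopropyl on a sulfur, which is the same change as the one from compound 1 to compound 2, at a place described in the same words. Because a step that the two limits leave unreadable from compound 1 to compound 2 is unreadable, the expected step that the limit leaves unreadable from compound 3 to compound 4 in this assay rests mainly on compound 3 itself, whose value > 3000 nM is a limit. Compound 4 is therefore expected to come out near 10000 nM, within roughly 3000 nM to 30000 nM, most likely again as a limit.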

Compound 4, half-maximal cytotoxic concentration: > 3000 nM
Compound 4 gave a limit, no number; the forecaster's own chance of this, stated with the estimate: 85%; the middle value lies beyond the limit too.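

In this assay compound 4 gives > 3000 nM, which is a limit of the assay and not a number. Compound 2 and compound 3 also carry only limits, and neither of their steps to compound 4 can be read. The compounds shown leave open how toxic each one actually is to these cells, and whether propyl in place of isopropyl on a sulfur changes that toxicity at all.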